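The compounds below may be only part of what the source reports. "The series", "measured", "known", "first", "only" and "open" are said of these compounds alone.

Measured compounds:
- compound 1, `COc1cccc2[nH]cc(C3(c4c[nH]c5cccc(OC)c45)C(=O)Nc4ccccc43)c12`: 15300 nM
- compound 2, `O=C1Nc2ccccc2C1(c1c[nH]c2ccc(Br)cc12)c1c[nH]c2ccc(Br)cc12`: 8000 nM
- compound 3, `COc1cccc2[nH]cc(C3(c4c[nH]c5cccc(OC)c45)C(=O)Nc4ccc(F)cc43)c12`: 7800 nM

The three measured compounds were tested in a functional assay on A549 cells (Homo sapiens) for cytotoxicity, read by MTT assay, with a stated time of 48 h; on this read-out lower numbers stand for stronger inhibition and higher numbers for weaker inhibition. Compound 1 gave 15300 nM, compound 3 gave 7800 nM and compound 2 gave 8000 nM. Compound 1 and compound 3 share one core, and the change between them is fluoro in place of hydrogen on an aromatic carbon. This change produced a 2.0-fold lower number from compound 1 to compound 3 (0.29 log units; within the scatter). Compound 2 rests on a different core; the difference between the two cores is not broken down here. The value of compound 2 lies within the scatter of both compound 1 and compound 3, so no order among the three can be read from these numbers.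

Compound 4, `O=C1Nc2ccc(F)cc2C1(c1c[nH]c2ccc(Br)cc12)c1c[nH]c2ccc(Br)cc12`, has not yet been measured in this assay. It differs from compound 2 by fluoro in place of hydrogen on an aromatic carbon, the same change as that from compound 1 to compound 3, made on the same kind of position. Since this change gave a 2.0-fold lower number from compound 1 to compound 3 (0.29 log units; within the scatter), a step of similar size from compound 2 to compound 4 is expected, that is a 1.6-fold lower number from compound 2 to compound 4 (0.20 log units; within the scatter), while noting that a single earlier step within the scatter is a weak basis. Compound 4 is therefore estimated at 5000 nM, most likely between 2000 nM and 12000 nM.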

Compound 4, half-maximal inhibitory concentration: 10300 nM
Compound 4: middle estimate off by 2.1-fold (0.31 log units), on the low side, within the range that was stated.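

In this assay, fluoro in place of hydrogen on an aromatic carbon gave a 1.3-fold higher number from compound 2 to compound 4 (0.11 log units; within the scatter), and the comparison with the same change on the other core reads: the same change on two cores in this assay, a 2.0-fold lower number (0.29 log units; within the scatter) from compound 1 to compound 3 and a 1.3-fold higher number (0.11 log units; within the scatter) from compound 2 to compound 4, 2.5-fold (0.40 log units) apart, within the scatter of two such steps. The two steps are written with different signs, but each of them, and the gap between them, lies within the scatter, so these numbers give no sign that the two cores answer this change differently, and the sign of either step carries no weight. Equally, they do not show that the change transfers reliably from one core to the other or that it has no effect at all, since two small steps could hide either a modest shared effect or a modest difference between the cores, and a firm statement would need steps that stand clear of the scatter.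

The compounds shown carry only hydrogen or fluoro at this aromatic carbon, so it remains open whether chloro, trifluoromethyl, a nitrile or an amine there would give a step beyond the scatter on either core. Also open, from the compounds shown here alone, is what would follow from replacing the amide hydrogen with a methyl group or a longer chain, on either core.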